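Working notes: nitro to bromo in the series

The compounds below may be only part of what the source reports. "The series", "measured", "known", "first", "only" and "open" are said of these compounds alone.

Measured in a functional assay on SMMC-7721 cells (Homo sapiens) for cytotoxicity, read by MTT assay, with a stated time of 24 h; on this read-out higher numbers stand for weaker inhibition and lower numbers for stronger inhibition:
- compound 1 `COc1cc(/C=C2\CN(C)C/C(=C\c3cccnc3)C2=O)cc(OC)c1`: 17900 nM
- compound 2 `O=C1/C(=C/c2cccnc2)CN(S(=O)(=O)c2ccccc2)C/C1=C\c1ccccc1F`: 19100 nM
- compound 3 `O=C1/C(=C/c2cccnc2)CN(S(=O)(=O)c2ccc([N+](=O)[O-])cc2)C/C1=C\c1ccccc1F`: > 20000 nM (a limit)

Compound 3 has no numerical value on this assay: its reading of > 20000 nM is a limit of the assay. Its place on the scale is the limit of > 20000 nM in this assay, at which 1 of the 3 values shown sits.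

The next compound is compound 4 `O=C1/C(=C/c2cccnc2)CN(S(=O)(=O)c2ccc(Br)cc2)C/C1=C\c1ccccc1F`. The change is bromo in place of nitro on an aromatic carbon, para to a large group, or 4-nitrophenyl to 4-bromophenyl.

Among the measured compounds shown here, only one measured step concerns this place on the ring: an at least 1.0-fold higher number from compound 2 to compound 3 (0.01 log units; that floor lies within the scatter). That step is nitro in place of hydrogen, and its floor lies within the scatter. On these data alone, its true size stays open, as it ends on a limit. For the measured compounds named here, no measured step has bromo entering, so the direction rests on thin evidence.

The nearest real number is that of compound 2 at 19100 nM, which carries hydrogen at this place. Compound 4 is therefore expected to read close to that number. The expected change is small, towards a lower number, and probably not beyond the scatter: an at least 1.2-fold lower number from compound 3 to compound 4 (0.09 log units; that floor lies within the scatter). A further reading at the limit would not be surprising.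

For compound 4 the estimated value is 16000 nM, with an expected range of 7000 nM to 30000 nM.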

Compound 4, half-maximal inhibitory concentration: 9100 nM
Estimate against measurement, compound 4: 1.8-fold (0.25 log units) above, and the stated range covers the measured number.
By their numbers in this assay, from the lowest: compounds 4, 1 and 2 (each within the scatter of the next, the first and the last beyond it). At a limit, above all of these: compound 3.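

In this assay, among the compounds shown here, the 4-bromophenyl group gives the first step at this place on the ring that has a real number at both ends and lies beyond the scatter: bromo in place of hydrogen gives a 2.1-fold lower number from compound 2 to compound 4 (0.32 log units; beyond the scatter). Bromo in place of nitro gives an at least 2.1-fold lower number from compound 3 to compound 4 (0.34 log units; beyond the scatter), so the group at this place can shift the read-out in either direction relative to nitro or hydrogen only as far as these steps show, and here the shift is modest and towards stronger inhibition. The earlier step at this place, an at least 1.0-fold higher number from compound 2 to compound 3 (0.01 log units; that floor lies within the scatter), could not show this, and compound 3 remains a limit and not a number, so the full size of the nitro to bromo change stays unfixed: the limit of > 20000 nM in this assay, at which 1 of the 4 values shown sits.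

How a chloro group, an amine or a carboxylic acid would read at this place remains open, so the three groups shown give no trend across groups. Also open, on these data alone, is whether the lower number of compound 4 holds when the fluoro group elsewhere on the shared core is exchanged, and whether it carries over to other cell lines.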